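Replacing a Ring with an Open Chain at the Linker

The compounds below may be only part of what the source reports. "The series", "measured", "known", "first", "only" and "open" are said of these compounds alone.

Of the compounds shown here, three sharing one core have been measured so far. In an assay on isolated protein for binding affinity to 5-hydroxytryptamine receptor 3A (Homo sapiens) (on this read-out lower numbers stand for stronger inhibition and higher numbers for weaker inhibition), compound 1 `CCc1nc2c(C(=O)NCC3CCN(CC(O)CN4CCN(S(C)(=O)=O)CC4)CC3)cccc2[nH]1` gives 79400 nM, compound 2 `CS(=O)(=O)N1CCN(CC(O)CN2CCC(CNC(=O)c3cccc4[nH]c(C5CC5)nc34)CC2)CC1` gives 50100 nM, and compound 3 `COC(=O)N1CCN(CCN2CCC(CNC(=O)c3cccc4[nH]c(C(C)C)nc34)CC2)CC1` gives 79400 nM. Compound 3 thus stands level with compound 1 at the digits shown, the two together forming the highest numbers of the three, while compound 2 lies a 1.6-fold lower number from compound 1 to compound 2 (0.20 log units; within the scatter) through a cyclopropyl in place of ethyl on an aromatic carbon, a difference that stays within the scatter.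

Compound 4 `COC(=O)N(C)CC(O)CN1CCC(CNC(=O)c2cccc3[nH]c(C(C)C)nc23)CC1` departs from compound 3 by 1-hydroxy-2-((methoxycarbonyl)(methyl)amino)ethyl in place of (4-(methoxycarbonyl)piperazin-1-yl)methyl on a saturated chain carbon bound to an amine nitrogen in a ring. Among the measured compounds shown here, no measured step touches this part of the molecule: the only step recorded, from compound 1 to compound 2, alters a substituent on the core and not the linker, so it offers no guidance on direction here. With all three measured numbers sitting within the scatter of one another, there is no basis for expecting compound 4 to move beyond that scatter in this assay in either direction. Compound 4 is therefore estimated at 80000 nM, with a range from 30000 nM to 250000 nM, which corresponds to an expected step of a 1.0-fold higher number from compound 3 to compound 4 (0.00 log units; within the scatter).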

Compound 4, inhibition constant: 50100 nM
Beside the measured number, compound 4's estimate is 1.6-fold (0.20 log units) above it, and the stated range covers the measured number.
By their numbers in this assay, from the lowest: compounds 2, 4, 1 and 3 (each within the scatter of the next).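

Among the compounds shown here, replacing (4-(methoxycarbonyl)piperazin-1-yl)methyl with 1-hydroxy-2-((methoxycarbonyl)(methyl)amino)ethyl on a saturated chain carbon bound to an amine nitrogen in a ring gives a 1.6-fold lower number from compound 3 to compound 4 (0.20 log units; within the scatter), the first measured step at this part of the molecule. The change removes a six-membered non-aromatic ring with 2 hetero atoms and brings in 1 hydrogen-bond donor, while the 3 hydrogen-bond acceptors and the absence of a net charge stay as they were, and even so the numbers of the two compounds in this assay remain within the scatter of each other. No accompanying data bear on the reason for this result.

The loss of the ring and the arrival of the hydroxy group come together in this one step, so the compounds shown cannot separate what each contributes. They also leave open whether a primary amine, a carboxylic acid or a longer chain at this place would carry the number in this assay beyond the scatter, and in which direction.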